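Chloro added to compound 2: cytotoxicity working notes

The compounds below may be only part of what the source reports. "The series", "measured", "known", "first", "only" and "open" are said of these compounds alone.

In an ADME assay on NIH3T3 cells (Mus musculus) for cytotoxicity, read by MTT assay, with a stated time of 24 h (on this read-out lower numbers stand for stronger inhibition and higher numbers for weaker inhibition), compound 1 `COc1cccc(N2CCN(CC(=O)N3CCN(c4nnc(-c5ccccc5)c(-c5ccccc5)n4)CC3)CC2)c1` gives 361000 nM. Compound 2 `COc1ccc(-c2nnc(N3CCN(C(=O)CN4CCN(c5ccccc5)CC4)CC3)nc2-c2ccc(OC)cc2)cc1` reaches only the assay limit, > 863000 nM, and is thus known only as a limit, not a number. Compound 2 stands at the limit of > 863000 nM in this assay, at which 1 of the 2 values shown sits. Compound 3 `COc1ccc(-c2nnc(N3CCN(C(=O)CN4CCN(c5ccccc5Cl)CC4)CC3)nc2-c2ccc(OC)cc2)cc1` differs from compound 2 by chloro in place of hydrogen on an aromatic carbon, ortho to a large group. Going by the values given here, no step between measured compounds is known, so no change beyond the usual scatter of this assay is expected, a step that the limit leaves unreadable from compound 2 to compound 3. Compound 3 is therefore expected at 900000 nM, between 400000 nM and 2000000 nM, most likely reported again as a limit.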

Compound 3, half-maximal inhibitory concentration: > 814000 nM
Compound 3 was reported as a limit; the forecaster's own chance of this, stated with the estimate: 70%; the middle value is on the limit's open side.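

Compound 2 and compound 3 are both known only as limits in this assay, so no step can be read between them. The compounds shown leave open whether chloro in place of hydrogen on an aromatic carbon changes cytotoxicity at all.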